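The source may report more compounds than this note shows. Statements on the series, on what has been measured and on what is new or still open speak of the compounds shown alone.

Compound 1 `Cc1ccc(C(=O)N2N=C(c3ccccc3)CC2c2cn(C)c3ccccc23)cn1`: 4010 nM
Compound 2 `COc1cc(C2=NN(C(=O)c3ccc(C)nc3)C(c3cn(C)c4ccccc34)C2)cc(OC)c1OC`: 180 nM
Compound 3 `Cn1cc(C2CC(c3ccc(Cl)cc3)=NN2C(=O)c2cccnc2)c2cc(Br)ccc21`: 8100 nM

In a functional assay on MCF7 cells (Homo sapiens) for inhibition, read by MTT assay, with a stated time of 48 h (on this read-out lower numbers stand for stronger inhibition of growth and higher numbers for weaker inhibition of growth), compound 3 gives the highest number of the three, 8100 nM. Compound 4 `COc1cc(C2=NN(C(=O)c3cccnc3)C(c3cn(C)c4ccc(Br)cc34)C2)cc(OC)c1OC` differs from it by one change, 3,4,5-trimethoxyphenyl in place of 4-chlorophenyl on a carbon with a double bond to nitrogen. Among the compounds with values here, one measured step bears on this, a large one: a 22-fold lower number from compound 1 to compound 2 (1.35 log units; beyond the scatter). There the same group replaced phenyl, not 4-chlorophenyl, and the rest of the structure differs from compound 3, so the transfer is uncertain. A large drop of similar size is expected, a 20-fold lower number from compound 3 to compound 4 (1.31 log units; beyond the scatter). Compound 4 is estimated at 400 nM, with an expected range from 120 nM to 1500 nM.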

Compound 4, concentration for 50% growth inhibition: > 10000 nM
Compound 4 was reported as a limit; the forecaster's own chance of this, stated with the estimate: 3%; at least 25-fold (1.39 log units) between middle value and limit.
By their numbers in this assay, from the lowest: compound 2; then compound 1; then compound 3. At a limit, above all of these: compound 4.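

In this assay, the 3,4,5-trimethoxyphenyl group on a carbon with a double bond to nitrogen did not bring a lower number in every setting: in place of 4-chlorophenyl it gave an at least 1.2-fold higher number from compound 3 to compound 4 (0.09 log units; that floor lies within the scatter). Compound 4 stands only at a limit: the limit of > 10000 nM in this assay, at which 1 of the 4 values shown sits.

Next to a 22-fold lower number from compound 1 to compound 2 (1.35 log units; beyond the scatter), this shows that the drop seen with this group does not carry over to a different rest of the structure. The compounds shown do not separate the bromine of compound 3 and compound 4 from the methyl of compound 1 and compound 2 as the source of this difference. Going by these compounds, how an amine or a carboxylic acid on the phenyl ring at this position would read also stays open.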